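A Larger Side Chain on Compound 2

The compounds below may be only part of what the source reports. "The series", "measured", "known", "first", "only" and "open" are said of these compounds alone.

Measured in a functional assay on KB cells (Homo sapiens) for inhibition; on this read-out higher numbers stand for weaker inhibition and lower numbers for stronger inhibition:
- Compound 1 `NC(=O)c1c(N)n(COCc2ccccc2)c2ncnc(N)c12`: > 100000 nM
- Compound 2 `CCCn1c(N)c(C#N)c2c(N)ncnc21`: 15000 nM

The entry for compound 1 at > 100000 nM is a limit of the assay and not a number. Within the data shown here, compound 2, at 15000 nM, therefore holds the only true number in this assay, and it is the sole anchor for what follows.

Compound 3 `Cc1ccc(Cn2c(N)c(C#N)c3c(N)ncnc32)cc1` has not yet been measured. It carries 4-methylphenyl in place of ethyl on a saturated chain carbon bound to an aromatic nitrogen.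

Among the measured compounds shown here, no two measured compounds differ in only one place, so no measured step indicates how large this change might be. Compound 1 also contains an aromatic ring, but it differs from compound 2 in more than one place and settles nothing here. A modest move towards stronger inhibition is expected, although a result within the scatter would be no surprise. The expected change is a 1.5-fold lower number from compound 2 to compound 3 (0.18 log units; within the scatter). In this assay the estimate for compound 3 is 10000 nM, with an expected range from 2000 nM to 60000 nM.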

Compound 3, half-maximal inhibitory concentration: > 100000 nM
Compound 3: a limit, no number; the forecaster's own chance of this, stated with the estimate: 20%; middle value at least 10-fold (1.00 log units) from the limit.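

Among these compounds, this is the first step in this assay between two compounds that differ in only one place, and it shows that this position is not indifferent to what it carries: putting 4-methylphenyl in place of ethyl on a saturated chain carbon bound to an aromatic nitrogen gives an at least 6.6-fold higher number from compound 2 to compound 3 (0.82 log units; beyond the scatter). Inhibition therefore weakens beyond the scatter with this change, which neither compound 1 nor compound 2 could show on its own, as they differ in more than one place. The entry for compound 3, > 100000 nM, is a limit of the assay and not a number, so the step sets only a minimum, and its true size cannot be read because of that limit: the limit of > 100000 nM in this assay, at which 2 of the 3 values shown sit.

The compounds shown leave open whether the weakening belongs to the aromatic ring itself, to its methyl group, or simply to the larger number of heavy atoms. They also leave open how a plain phenyl, a longer chain or a chain ending in an amine would compare with compound 2 at this position.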